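Opening the Ring of Compound 3

A few compounds are considered here, and "the series" means these few. Any claim that something is new, unique, unknown or untested is made for them only; others in the source may bear on it.

Compound 2 `O=C(CCCCC1CCSS1)Nc1ccc(Cl)cn1` and compound 3 `O=C(CCCCC1CCSS1)Nc1ccc(Br)cn1` differ only in one halogen. In a functional assay on Bel-7402 cells (Homo sapiens) for inhibition, read by MTT assay, with a stated time of 24 h, tested at 1 ug/mL (a lower number here means less inhibition of growth, a higher number more inhibition of growth at the concentration tested), compound 2 gives 7.44% and compound 3 gives 13.1%. Within the data shown here, compound 3 therefore stands level with compound 2, since the only measured step, a number 5.7 percentage points higher from compound 2 to compound 3 (within the scatter), stays within the scatter. Compound 1 `O=C(O)CCCCC(CCSC(=O)c1ccccc1)SC(=O)c1ccccc1`, which has an open chain, is reported as "not active" (no number reported), without a number.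

Compound 4 `O=C(CCCCC(S)CCS)Nc1ccc(Br)cn1` keeps the rest of compound 3 and changes one part: a group of 5 heavy atoms (3 carbon, 2 sulfur; no ring) in place of a group of 5 heavy atoms (3 carbon, 2 sulfur; one five-membered non-aromatic ring with 2 hetero atoms), on a saturated chain carbon, four bonds along the chain from a carbonyl carbon. Among the measured compounds shown here, no measured step covers this ring opening. For the measured compounds named here, the halogen swap shows only that both ring-bearing compounds sit close together. Compound 1 also lacks the ring but differs elsewhere too, so it serves only as a warning that the reading could fall to nothing. No step beyond the scatter can be predicted in either direction. The expected change is small, a number 1.1 percentage points lower from compound 3 to compound 4 (within the scatter), and the range is kept wide. For compound 4 the estimated value is 12%, with an expected range of 3% to 25%.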

Compound 4, percent growth inhibition at one concentration: 4.71%
Compound 4: the middle estimate sits 7.3 percentage points above what was measured; the measured number falls inside the stated range.
By their numbers in this assay, from the lowest: compounds 4, 2 and 3 (each within the scatter of the next).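

Replacing the ring with the open 1,3-disulfanylpropyl group, on a saturated chain carbon, four bonds along the chain from a carbonyl carbon, gives a number 8.4 percentage points lower from compound 3 to compound 4 (within the scatter) in this assay. The ring can therefore be opened here, changing the group from 0 to 2 hydrogen-bond donors, without a step beyond the scatter, so this pair does not show that the closed ring matters for the reading at this single concentration. No measurement shown here accounts for the reading of compound 4.

With compounds 2, 3 and 4 all within the scatter of one another, this position has not yet produced a clear difference. Still open, going by these compounds, is whether a longer chain before the sulfur-bearing group, or an amine in place of one sulfur group, would move the reading beyond the scatter.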